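Inverting the hydroxyl stereocentre of an azido sphingosine phosphate

A few compounds are considered here, and "the series" means these few. Any claim that something is new, unique, unknown or untested is made for them only; others in the source may bear on it.

Measured compounds:
compound 1, `CCCCCCCCCCCCC/C=C/[C@H](O)[C@H](COP(=O)(O)O)N=[N+]=[N-]`, 28800 nM
compound 2, `CCCCCCCCCCCCCCC[C@H](O)[C@@H](COP(=O)(O)O)N=[N+]=[N-]`, 10800 nM
compound 3, `CCCCCCCCCCCCCCC[C@@H](O)[C@H](COP(=O)(O)O)N=[N+]=[N-]`, 25700 nM

Compound 1 stands highest of the three numbers in an assay on isolated protein for inhibition of sphingosine-1-phosphate lyase 1 (Homo sapiens), read by fluorescence, with a stated time of 1 h; on this read-out lower numbers stand for stronger inhibition and higher numbers for weaker inhibition. Its nearest neighbour is compound 3, whose value lies within the scatter of compound 1, while compound 2 gives the lowest number of the set, beyond the scatter from compound 1.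

The step to compound 4, `CCCCCCCCCCCCC/C=C/[C@@H](O)[C@H](COP(=O)(O)O)N=[N+]=[N-]`, changes compound 1 only in its drawn configuration: the two compounds have the same atoms and bonds; at least one stereo element is drawn with a configuration in one of them and without one in the other: 1 of 4 stereo elements differ; a stereocentre at a saturated chain carbon is drawn S in compound 1 and R in compound 4. Among the measured compounds shown here, the only measured step that touches configuration is a 2.4-fold higher number from compound 2 to compound 3 (0.38 log units; beyond the scatter), which is attributed to the fact that one of compounds 2 and 3 is drawn with a defined configuration and the other without, at the place where they differ. That step, however, inverts both chain stereocentres at once, whereas the change from compound 1 to compound 4 inverts a single one, so it gives only a loose guide. A modest step is therefore expected in this assay, its direction uncertain, and compound 1 already sits at the weak end of the range. For compound 4 the estimate is 20000 nM, between 8000 nM and 60000 nM, which is expected to amount to a 1.4-fold lower number from compound 1 to compound 4 (0.16 log units; within the scatter).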

Compound 4, half-maximal inhibitory concentration: 10100 nM
Estimate against measurement, compound 4: 2.0-fold (0.30 log units) above; measured number inside the range.
By their numbers in this assay, from the lowest: compounds 4 and 2 (each within the scatter of the next); then compounds 3 and 1 (each within the scatter of the next).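

In this assay, the change of a single stereocentre at a saturated chain carbon, drawn S in compound 1 and R in compound 4, gives a 2.9-fold lower number from compound 1 to compound 4 (0.46 log units; beyond the scatter). The earlier configurational step, a 2.4-fold higher number from compound 2 to compound 3 (0.38 log units; beyond the scatter), changed two stereo elements at once, so it could not show that one inverted centre is enough to move the number beyond the scatter. The two compounds have the same atoms and bonds, so this step can be traced to configuration alone: the fact that one of compounds 1 and 4 is drawn with a defined configuration and the other without, at the place where they differ

The compounds shown leave open whether inverting this one centre would have a similar effect in the saturated series, where only the double inversion can be read. Also open, from the compounds shown here alone, is how this assay would respond to an amine in place of the azide or a carboxylic acid in place of the phosphate.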